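Working notes: removing the chloro group from compound 3

A few compounds are considered here, and "the series" means these few. Any claim that something is new, unique, unknown or untested is made for them only; others in the source may bear on it.

All four compounds share one core, carried unchanged across the series. Compound 1 `O=c1c(C2N=C(c3ccccc3)SS2)coc2ccc(Cl)cc12` gives 71% in a functional assay on OVCAR-3 cells (Homo sapiens) for inhibition, read by sulforhodamine B assay, with a stated time of 48 h, tested at 100 uM; on this read-out higher numbers stand for more inhibition of growth at the one concentration tested and lower numbers for less inhibition of growth. Among the measured compounds shown here, compound 2 `O=c1c(C2N=C(c3ccccc3)SS2)coc2ccc(F)cc12` gives 27% in this assay; the single step measured so far, a number 44 percentage points lower from compound 1 to compound 2 (beyond the scatter), is the only change that has been followed directly. Compound 3 `O=c1c(C2N=C(c3ccccc3)SS2)coc2cc(Cl)ccc12` gives 91% in this assay and stands highest of the three numbers, with compound 1 nearest and compound 2 furthest, both gaps beyond the scatter.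

Compound 4 `O=c1c(C2N=C(c3ccccc3)SS2)coc2ccccc12` is not yet measured. It differs from compound 3 by hydrogen in place of chloro on an aromatic carbon. For the measured compounds named here, no measured pair removes a halogen altogether, so the bearing of the existing data is indirect: the one step known, a number 44 percentage points lower from compound 1 to compound 2 (beyond the scatter), exchanges one halogen for another on a different aromatic carbon and was large and downward. Going from chloro to hydrogen is a further move in the same direction of shrinking the substituent, so a downward step in this assay is expected for compound 4, with a wide range, since no measured pair shows this exact change. For compound 4 the expected value is 55%, within 25% to 85%, corresponding to an estimated step of a number 36 percentage points lower from compound 3 to compound 4 (beyond the scatter).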

Compound 4, percent growth inhibition at one concentration: 11%
For compound 4 the middle estimate is 44 percentage points above the measured one; measured number outside the range, below it.
By their numbers in this assay, from the lowest: compound 4; then compound 2; then compound 1; then compound 3.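

Removing the halogen outright now has a direct reading in this assay: hydrogen in place of chloro on the aromatic carbon meta to a fused ring and para to a fused ring gives a number 80 percentage points lower from compound 3 to compound 4 (beyond the scatter) and on the chloro-bearing carbon of compound 1 gives a number 60 percentage points lower from compound 1 to compound 4 (beyond the scatter) so at both places the chloro group is tied to most of the growth inhibition read at the one concentration tested. Hydrogen in place of fluoro gives a smaller change, a number 16 percentage points lower from compound 2 to compound 4 (beyond the scatter) and still points the same way, so compound 4 stands below all three halogen-bearing compounds, with none of the compounds shown going against this order. No measurement at hand bears on what lies behind these drops.

Open, going by these compounds, is whether a bromo group, a methoxy group or an amine on the same aromatic carbon would hold growth inhibition as chloro does in compound 3, or fall towards compound 4. Also open is whether fluoro at the place of the chloro group in compound 3 would stay as low as fluoro does in compound 2, and whether the order among these compounds would hold at other concentrations.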